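Removing a Butyl Branch from a Bombesin Receptor Agonist

This account rests on a few compounds, and the source may have more. Where it says the series, first, only, none or still open, it means among the compounds named here.

Measured compounds:
compound 1, `Cc1ccccc1Cc1cnc(CCc2ccc(-c3ccccc3C(=O)O)cc2)[nH]1`: 127 nM
compound 2, `CCCCc1cnc(C(CCCC)Cc2ccc(-c3ccccc3C(=O)O)cc2)[nH]1`: 2660 nM

Both compounds were tested in an in vitro functional assay on cells for agonist activity at Bombesin receptor subtype-3 (Homo sapiens), read by luminescence and calcium flux; a higher number here means that more compound is needed for the effect, a lower number that less compound is needed. Compound 2 stands with the highest of the two numbers; compound 1 gives a markedly lower number, and that gap lies beyond the usual scatter. The two differ in more than one place, so the gap cannot be assigned to a single change.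

Compound 3, `CCCCc1cnc(CCc2ccc(-c3ccccc3C(=O)O)cc2)[nH]1`, has not been measured yet. It differs from compound 2 by hydrogen in place of butyl on a saturated chain carbon bound to an aromatic carbon and a saturated chain carbon. Compound 1 carries a hydrogen at that same chain position and gives the lower number, so a step downward in this assay is expected for compound 3, larger than the scatter, though the other difference between compound 1 and compound 2 leaves the size uncertain. The estimated step for compound 3 is a 7.6-fold lower number from compound 2 to compound 3 (0.88 log units; beyond the scatter). Compound 3 is expected to give 350 nM, within a range from 90 nM to 1400 nM.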

Compound 3, half-maximal effective concentration: 2710 nM
Compound 3: middle estimate off by 7.7-fold (0.89 log units), on the low side; measured number outside the range, above it.
By their numbers in this assay, from the lowest: compound 1; then compounds 2 and 3 (each within the scatter of the next).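

In this assay, hydrogen in place of butyl on this saturated chain carbon leaves the number within the scatter (a 1.0-fold higher number from compound 2 to compound 3 (0.01 log units; within the scatter)), so with the butyl group on the other side of compound 3, this branch makes no measurable difference. The large gap between compound 1 and compound 3 belongs to the other place, where propyl stands in place of 2-methylphenyl on a saturated chain carbon bound to an aromatic carbon (a 21-fold higher number from compound 1 to compound 3 (1.33 log units; beyond the scatter)). Nothing shown here gives a reason for either result.

Open, on these data alone, is whether the butyl branch would still make no measurable difference in a compound that keeps the 2-methylphenyl group. Also open, as far as these compounds go, is how a methyl branch or an amine on the same chain carbon would behave in this assay series.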